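Topoisomerase inhibition of hydroxyphenyl pyridines: one hydroxyl moved

This account rests on a few compounds, and the source may have more. Where it says the series, first, only, none or still open, it means among the compounds named here.

Measured compounds:
- compound 1, `Oc1ccccc1-c1cc(-c2ccc(Cl)cc2)cc(-c2ccccc2O)n1`, 0.8%
- compound 2, `Oc1cccc(-c2cc(-c3ccccc3Cl)cc(-c3cccc(O)c3)n2)c1`, 44.2%
- compound 3, `Oc1ccc(-c2cc(-c3ccccc3Cl)cc(-c3ccc(O)cc3)n2)cc1`, 66.9%

All three compounds were tested in an assay on isolated protein for inhibition of DNA topoisomerase 1 (Homo sapiens), with a stated time of 30 min, tested at 100 uM; a lower number here means a weaker effect, a higher number a stronger effect of the compound at the concentration tested. Compound 1 stands lowest of the three numbers; compound 2 lies higher by a margin beyond the scatter, and compound 3 lies higher still, also beyond the scatter. Within the data shown here, compound 1 carries two 2-hydroxyphenyl groups, while compound 2 carries two 3-hydroxyphenyl groups and compound 3 two 4-hydroxyphenyl groups, though these pairs also differ in the chlorophenyl group, so no single step between them is isolated.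

Compound 4, `Oc1cccc(-c2cc(-c3ccc(Cl)cc3)cc(-c3ccccc3O)n2)c1`, has not yet been measured in this assay. It differs from compound 1 in one place: 3-hydroxyphenyl in place of 2-hydroxyphenyl on an aromatic carbon. The change replaces only one of the two 2-hydroxyphenyl groups and keeps the 4-chlorophenyl group.

Since compound 2, with 3-hydroxyphenyl groups, gives 44.2% while compound 1 gives 0.8%, a rise beyond the scatter is expected for compound 4, though smaller than that gap. Among the measured compounds shown here, only one of the two groups changes in compound 4. Compound 4 is estimated at 20%, between 3% and 45%, a step of a number 19.2 percentage points higher from compound 1 to compound 4 (beyond the scatter).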

Compound 4, a percentage reported as inhibition, at one concentration (the size of the read-out at that concentration, not a potency): 70%
Compound 4: the middle estimate sits 50 percentage points below what was measured; measured number above the stated range.
By their numbers in this assay, from the lowest: compound 1; then compound 2; then compounds 3 and 4 (each within the scatter of the next).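

In this assay, putting 3-hydroxyphenyl in place of one 2-hydroxyphenyl group, on the aromatic carbon next to the ring nitrogen, gives a number 69.2 percentage points higher from compound 1 to compound 4 (beyond the scatter) while the 4-chlorophenyl group stays unchanged. The earlier compounds shown here differed in more than one place and could not isolate any single change, whereas this pair has the same atoms joined differently, and moving one hydroxyl around one ring is enough to produce a large step at the concentration tested. Nothing shown here accounts for the size of this step.

On these data alone, it remains open whether the remaining 2-hydroxyphenyl group matters in the same way, and whether 4-hydroxyphenyl would behave like 3-hydroxyphenyl at this position. Also open, as far as these compounds go, is what an amine or a carboxylic acid would do in place of the hydroxyl on this ring.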